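The source may hold more compounds than are shown below. What is called first, only, known or untested is meant among the compounds shown, and "the series" means these compounds.

Three compounds in this series share one core. Compound 1 `[O-][n+]1nc(NCOCc2ccc(Cl)cc2)[n+]([O-])c2ccccc21` gives 5760 nM in a functional assay on PC-3 cells (Homo sapiens) for cytotoxicity, read by MTT assay, with a stated time of 72 h; a higher number here means a weaker inhibitor, a lower number a stronger inhibitor. Compound 2 `COc1ccc(COCNc2n[n+]([O-])c3ccccc3[n+]2[O-])cc1` gives 14500 nM in this assay, and compound 3 `CCCOCNc1n[n+]([O-])c2ccccc2[n+]1[O-]` gives 14200 nM in this assay. Compound 3 thus stands second highest of the three: the step of a 1.0-fold lower number from compound 2 to compound 3 (0.01 log units; within the scatter) is within the scatter, whereas a 2.5-fold higher number from compound 1 to compound 3 (0.39 log units; beyond the scatter) lies beyond it. Compound 4 `CCCCCCCOCNc1n[n+]([O-])c2ccccc2[n+]1[O-]` differs from compound 3 by butyl in place of hydrogen on a saturated chain carbon, three bonds along the chain from an oxygen on a saturated carbon. Within the data shown here, no measured step lengthens the chain in this way; the steps that alter this part of the molecule, a 2.5-fold higher number from compound 1 to compound 3 (0.39 log units; beyond the scatter) and a 1.0-fold lower number from compound 2 to compound 3 (0.01 log units; within the scatter), were modest or within the scatter, so only a small change in this assay is expected, in either direction. Accordingly the expected step is a 1.4-fold lower number from compound 3 to compound 4 (0.15 log units; within the scatter). Compound 4 is estimated at 10000 nM, with a range from 4000 nM to 30000 nM.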

Compound 4, half-maximal inhibitory concentration: 1210 nM
Estimate against measurement, compound 4: 8.3-fold (0.92 log units) above; the whole stated range lies above it.
By their numbers in this assay, from the lowest: compound 4; then compound 1; then compounds 3 and 2 (each within the scatter of the next).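

In this assay this chain position proves highly responsive: butyl in place of hydrogen gives a large step (a 12-fold lower number from compound 3 to compound 4 (1.07 log units; beyond the scatter)), whereas earlier changes here were modest or within the scatter. Hexyl also surpasses both aryl groups, by a large step over 4-methoxyphenyl (a 12-fold lower number from compound 2 to compound 4 (1.08 log units; beyond the scatter)) and a modest one over 4-chlorophenyl (a 4.8-fold lower number from compound 1 to compound 4 (0.68 log units; beyond the scatter)). Nothing available explains this gain. From the compounds shown here alone, whether a longer chain such as octyl or decyl would continue this trend remains open. So does the effect of an amine at the chain end.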